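The source may hold more compounds than are shown below. What is called first, only, known or untested is meant among the compounds shown, and "the series" means these compounds.

Measured so far:
Compound 1 `CC(O)(C(=O)Nc1ccc(S(=O)(=O)c2ccccc2)c(C#N)c1)C(F)(F)F` gives 3800 nM in a functional assay (Cavia porcellus) with sulfonylurea receptors; K-ATP channels (Homo sapiens) as the target; on this read-out lower numbers stand for stronger inhibition and higher numbers for weaker inhibition.
Compound 2 `CC(O)(C(=O)Nc1ccc(S(=O)(=O)c2ccccc2)c(O)c1)C(F)(F)F` gives 430 nM in this assay.

Among the compounds with values here, compound 2 holds the lower of the two numbers, and its only neighbour is compound 1, whose number is higher by a step that lies beyond the scatter: an 8.8-fold lower number from compound 1 to compound 2 (0.95 log units; beyond the scatter). The change that produced that step was a hydroxy in place of a cyano on the aromatic carbon of the shared core.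

Compound 3 `CC(O)(C(=O)Nc1ccc(S(=O)(=O)c2ccccc2)c(Cl)c1)C(F)(F)F` is not yet measured. It differs from compound 2 in a single place: chloro in place of hydroxy on an aromatic carbon. Within the data shown here, the one measured step that bears on this position is the one from compound 1 to compound 2, and it was modest in size. That step shows the position is sensitive to what sits on it, but neither cyano nor hydroxy is chloro, so the direction for compound 3 cannot be read from it with confidence. Among the measured compounds shown here, because the only comparison, an 8.8-fold lower number from compound 1 to compound 2 (0.95 log units; beyond the scatter), shows both a higher and a lower number are possible here, compound 3 is expected to land between them, and the estimated step is a 3.5-fold higher number from compound 2 to compound 3 (0.54 log units; beyond the scatter). Compound 3 is thus estimated at 1500 nM, within a range from 400 nM to 6000 nM.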

Compound 3, half-maximal inhibitory concentration: 2200 nM
Compound 3: middle estimate off by 1.5-fold (0.17 log units), on the low side, and the stated range covers the measured number.
By their numbers in this assay, from the lowest: compound 2; then compounds 3 and 1 (each within the scatter of the next).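

In this assay the hydroxy of compound 2 now stands apart from two other groups on this aromatic carbon rather than one, since chloro in its place gives a 5.1-fold higher number from compound 2 to compound 3 (0.71 log units; beyond the scatter) and that step is of the same modest class as the earlier one involving the nitrile. Chloro and the nitrile are not told apart here, as the change between them gives a 1.7-fold lower number from compound 1 to compound 3 (0.24 log units; within the scatter) and that step lies within the scatter. The position therefore does not show a graded series across these three compounds; it shows only a split between hydroxy on one side and chloro and the nitrile on the other, with the change from hydroxy to chloro taking away 1 hydrogen-bond donor and 1 hydrogen-bond acceptor.

The compounds shown leave open whether an amine, a methoxy group or a carboxylic acid on this carbon would fall with hydroxy or with chloro and the nitrile, and whether a bare hydrogen there would match either side. No measurement offered here accounts for the split between hydroxy and the other two groups.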